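Cyclohexyl for Methoxyphenyl on the Ring Amide Nitrogen

The source may hold more compounds than are shown below. What is called first, only, known or untested is meant among the compounds shown, and "the series" means these compounds.

Compound 1, `O=C1COc2ccc(-c3cccc(NS(=O)(=O)c4ccc(F)cc4)c3)cc2N1C1CC1`: > 40000 nM
Compound 2, `COc1ccc(N2C(=O)COc3ccc(-c4cnc(OC)c(NS(=O)(=O)c5ccc(F)cc5)c4)cc32)cc1`: 13100 nM

Of the compounds shown here, two have been measured in a functional assay on HepG2 cells (Homo sapiens) for antiproliferative activity, read by MTT assay, with a stated time of 72 h; on this read-out lower numbers stand for stronger inhibition and higher numbers for weaker inhibition. For compound 1 the result is only a limit of the assay, > 40000 nM. Compound 2 gives 13100 nM in this assay, the only number shown. The other result, that of compound 1, is a limit of the assay, as recorded by the limit of > 40000 nM in this assay, at which 1 of the 2 values shown sits. For the measured compounds named here, compounds 1 and 2 differ in more than one place, so no single step connects them.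

Compound 3, `COc1ncc(-c2ccc3c(c2)N(C2CCCCC2)C(=O)CO3)cc1NS(=O)(=O)c1ccc(F)cc1`, has not yet been measured. It differs from compound 2 in one place: cyclohexyl in place of 4-methoxyphenyl on an amide-type nitrogen in a ring. Going by the values given here, no measured step bears on this change, so its direction cannot be read from the data. Compound 3 is expected to land close to compound 2 or a little weaker in this assay, the estimated step being a 1.5-fold higher number from compound 2 to compound 3 (0.18 log units; within the scatter). The estimate for compound 3 is 20000 nM, with a range from 6000 nM to 60000 nM.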

Compound 3, half-maximal inhibitory concentration: > 40000 nM
Compound 3 ended at the assay's limit; the forecaster's own chance of this, stated with the estimate: 30%; middle value at least 2.0-fold (0.30 log units) from the limit.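

In this assay, for the compounds shown here, replacing 4-methoxyphenyl with cyclohexyl on the amide-type nitrogen gives the only measured step at this position, an at least 3.0-fold higher number from compound 2 to compound 3 (0.48 log units; beyond the scatter). The position is therefore not indifferent to its group: with the rest of compound 2 kept, this change weakens inhibition beyond the scatter. Compound 3 sits at a limit of the assay, so the step gives only a lower bound on the loss and not its size: the limit of > 40000 nM in this assay, at which 2 of the 3 values shown sit.

Going by these compounds, whether the loss follows from giving up the aromatic ring or the methoxy oxygen of the 4-methoxyphenyl group stays open. Plain phenyl on the same nitrogen would separate the two, and the compounds shown also leave open whether any other group here would bring a number lower than that of compound 2.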